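The source may hold more compounds than are shown below. What is called first, only, known or untested is meant among the compounds shown, and "the series" means these compounds.

Compound 1, `Cc1ccc(C(=O)NC2CCCCCC2)c(=O)n1Cc1ccc(F)cc1`, gives > 10000 nM in an assay on HEK293 cells for inhibition of Monoacylglycerol lipase ABHD6 (Homo sapiens), read by scintillation counting, with stated times of 30 min and 5 min (a lower number here means a stronger inhibitor, a higher number a weaker inhibitor), which is a limit of the assay and not a number.
Compound 2, `Cc1c(Cl)cc(C(=O)NC2CCCCCC2)c(=O)n1Cc1ccc(F)cc1`, gives > 10000 nM in this assay, again a limit.
Compound 3, `Cc1ccc(C(=O)NC2CCCCCC2)c(OCc2ccc(F)cc2)n1`, gives > 10000 nM in this assay, also a limit.

Compound 3 therefore stands at no measured number at all: it sits at the limit of > 10000 nM in this assay, at which 3 of the 3 values shown sit, together with every other value shown. Within the data shown here, the only step between measured compounds that differ in one place is a step that the two limits leave unreadable from compound 1 to compound 2, and since both ends of it are limits, its size cannot be read. That step, like the change now considered, puts a halogen where hydrogen stood, and it is the closest comparison available.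

Compound 4, `Cc1nc(OCc2ccc(F)cc2)c(C(=O)NC2CCCCCC2)cc1Br`, differs from compound 3 by bromo in place of hydrogen on an aromatic carbon. Among the measured compounds shown here, the single step that bears on this change gives no readable size, and compound 3 itself offers only a limit, so there is no ground to expect a step in this assay beyond the scatter in either direction; the expectation is simply that compound 4 remains at the limit. Compound 4 is therefore estimated at 20000 nM, within 5000 nM to 100000 nM. The step this estimate means, a step that the limit leaves unreadable from compound 3 to compound 4, is expected to be no change.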

Compound 4, half-maximal inhibitory concentration: > 10000 nM
Compound 4 ended at the assay's limit; the forecaster's own chance of this, stated with the estimate: 90%; the middle value does not contradict the limit.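

Compound 3 and compound 4 both give limits and not numbers, so the step between them cannot be read, and bromo in place of hydrogen shows no size in this assay. All the compounds shown stand at the same place: the limit of > 10000 nM in this assay, at which 4 of the 4 values shown sit. They leave open which change to the shared core, if any, would give a measurable value in this assay.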